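The source may hold more compounds than are shown below. What is called first, only, known or untested is meant among the compounds shown, and "the series" means these compounds.

Compound 1 `COc1cc(/C=N/NC(=O)CCN2CCN(c3ccnc4cc(Cl)ccc34)CC2)ccc1OC(C)C` serves as the reference point; in an ADME assay on cells (Splenocyte, Mus musculus, strain BALB/c) for cytotoxicity, read by thymidine incorporation, with a stated time of 24 h (on this read-out lower numbers stand for stronger inhibition and higher numbers for weaker inhibition), compound 1 gives 8800 nM. Compound 2 `O=C(CCN1CCN(c2ccnc3cc(Cl)ccc23)CC1)N/N=C/c1cccc(Cl)c1` carries a 3-chlorophenyl in its place. For compound 2 this assay reports only a limit, > 100000 nM. As far as these compounds go, the step of an at least 11-fold higher number from compound 1 to compound 2 (1.05 log units; beyond the scatter) is thus bounded by the limit of > 100000 nM in this assay, at which 1 of the 2 values shown sits, and its true size stays open. Compound 3 `CC(C)c1ccc(/C=N/NC(=O)CCN2CCN(c3ccnc4cc(Cl)ccc34)CC2)cc1` differs from compound 2 by 4-isopropylphenyl in place of 3-chlorophenyl on a carbon with a double bond to nitrogen. For the measured compounds named here, the only measured step touching this position is the large one just described, which shows the 3-chlorophenyl far weaker than the 4-isopropoxy-3-methoxyphenyl. A 4-isopropylphenyl resembles the aryl group of compound 1 more closely than the 3-chlorophenyl does, though it lacks the methoxy, so a move back toward a lower number is expected, of uncertain size. Since compound 1 gives 8800 nM, compound 3 is expected near 30000 nM, within 8000 nM to 150000 nM, which amounts to an at least 3.3-fold lower number from compound 2 to compound 3 (0.52 log units; beyond the scatter) in this assay.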

Compound 3, half-maximal inhibitory concentration: 7900 nM
Estimate against measurement, compound 3: 3.8-fold (0.58 log units) above; the measured number lies below the stated range.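

In this assay, the exchange of 4-isopropoxy-3-methoxyphenyl for 4-isopropylphenyl on a carbon with a double bond to nitrogen gives a 1.1-fold lower number from compound 1 to compound 3 (0.05 log units; within the scatter), so the two aryl groups are not separated at this position and the methoxy is not required to hold the value of compound 1. The 3-chlorophenyl, by contrast, stands apart from both, with an at least 12-fold lower number from compound 2 to compound 3 (1.10 log units; beyond the scatter). Compound 2 gives only a limit, so this step remains a bound and its true size stays open: the limit of > 100000 nM in this assay, at which 1 of the 3 values shown sits.

As far as these compounds go, how an unsubstituted phenyl would compare at this position remains open, as does whether the chlorine of compound 2 alone accounts for the gap. A phenyl carrying an amine or a carboxylic acid is also untested among the compounds shown.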